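Changing the Pyridine Ring: From Compound 2 to Compound 4

The compounds below may be only part of what the source reports. "The series", "measured", "known", "first", "only" and "open" are said of these compounds alone.

Of the compounds shown here, three have been measured in a functional assay on MCF7 cells (Homo sapiens) for cytotoxicity, read by MTT assay, with a stated time of 72 h; a higher number here means a weaker inhibitor, a lower number a stronger inhibitor.

Compound 1 `Cc1cccc(/C(N)=N/NC(=S)N2CCCCC2)n1` gives 74000 nM.
Compound 2 `N/C(=N\NC(=S)N1CCN(c2ccccn2)CC1)c1ccc(F)cn1` gives 22000 nM.
Compound 3 `N/C(=N\NC(=S)N1CCCCCC1)c1ccccn1` gives 2600 nM.

Compound 2 holds the second highest number of the three. Compound 1 sits above it by a gap beyond the usual scatter, and compound 3 sits below it by a larger gap, also beyond the scatter, so compound 2 stands between a weaker and a stronger inhibitor. Compound 4 `Cc1cccc(/C(N)=N/NC(=S)N2CCN(c3ccccn3)CC2)n1` has not yet been measured. Its change from compound 2 is 6-methylpyridin-2-yl in place of 5-fluoropyridin-2-yl on a carbon with a double bond to nitrogen. Among the compounds with values here, no pair of measured compounds differs in only one place, so the effect of this change cannot be read from a direct comparison. A loose hint comes from compound 1, which also carries the 6-methylpyridin-2-yl group and gives 74000 nM, though it differs from compound 2 in more than one place. The expected step is a 1.8-fold higher number from compound 2 to compound 4 (0.26 log units; within the scatter), towards a higher number, possibly beyond the scatter. The estimate for compound 4 is 40000 nM, within a range from 12000 nM to 130000 nM.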

Compound 4, half-maximal inhibitory concentration: > 100000 nM
Compound 4: only a limit was reported; the forecaster's own chance of this, stated with the estimate: 10%; middle value at least 2.5-fold (0.39 log units) away from the limit.
By their numbers in this assay, from the lowest: compound 3; then compound 2; then compound 1. At a limit, above all of these: compound 4.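

In this assay compound 4 gives > 100000 nM as a limit of the assay, not a number. Within the data shown here, putting 6-methylpyridin-2-yl in place of 5-fluoropyridin-2-yl on a carbon with a double bond to nitrogen gives an at least 4.5-fold higher number from compound 2 to compound 4 (0.65 log units; beyond the scatter) in the only comparison here that differs in one place, so this change alone moves the result beyond the scatter, towards a weaker inhibitor. That step is only a minimum, and its true size stays unknown because the result rests on a limit: the limit of > 100000 nM in this assay, at which 1 of the 4 values shown sits.

The compounds shown cannot separate the loss of the fluorine from the gain of the methyl, so neither can be credited with the step. The same core carrying a methoxy group or a chlorine atom on the pyridine ring would be needed to show how far this position tolerates other groups.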